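This account rests on a few compounds, and the source may have more. Where it says the series, first, only, none or still open, it means among the compounds named here.

Working notes on the series. In a functional assay on MCF7 cells (Homo sapiens) for antiproliferative activity, read by MTT assay, with a stated time of 48 h (a higher number here means a weaker inhibitor, a lower number a stronger inhibitor), compound 1 `COc1ccc(C(=O)c2ccc(OC)c3c2C=CC(C)(C)O3)c(NC(=O)CBr)c1` gives (3290 nM), compound 2 `COc1ccc(C(=O)c2ccc(OC)c3c2OC(C)(C)C=C3)c(NC(=O)CO)c1` gives (320 nM) and compound 3 `COc1ccc(C(=O)c2ccc(OC)c3c2OC(C)(C)C=C3)c(NC(=O)CN)c1` gives (410 nM). Compound 3 thus lies within the scatter of compound 2 and carries a clearly lower number than compound 1.

Compound 4 `COc1ccc(C(=O)c2ccc(OC)c3c2OC(C)(C)C=C3)c(NC(=O)CN(C)C)c1` differs from compound 3 by dimethylamino in place of amino on a saturated chain carbon bound to a carbonyl carbon and has dimethylamino in place of amino on a saturated chain carbon bound to a carbonyl carbon.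

For the measured compounds named here, one measured step bears on this place: a 1.3-fold higher number from compound 2 to compound 3 (0.11 log units; within the scatter) for amino in place of hydroxy, a change that stays within the scatter. Compound 1 differs from compound 3 in more than one place and gives no clean comparison. Going by the values given here, no measured compound yet carries dimethylamino, so the basis is thin and the range is kept wide.

In this assay the expected step of a 1.2-fold higher number from compound 3 to compound 4 (0.07 log units; within the scatter) is not expected to exceed the scatter, with no firm direction.

For compound 4 the estimated value is 480 nM with an expected range from 170 nM to 1400 nM in this series.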

Compound 4, half-maximal inhibitory concentration: 2680 nM
For compound 4 the middle estimate is 5.6-fold (0.75 log units) below the measured one, outside the stated range (above it).
By their numbers in this assay, from the lowest: compounds 2 and 3 (each within the scatter of the next); then compounds 4 and 1 (each within the scatter of the next).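

In this assay this place, on a saturated chain carbon bound to a carbonyl carbon, turns out not to accept every group alike: dimethylamino in place of amino gives a 6.5-fold higher number from compound 3 to compound 4 (0.82 log units; beyond the scatter) and dimethylamino in place of hydroxy gives an 8.4-fold higher number from compound 2 to compound 4 (0.92 log units; beyond the scatter). For the compounds shown here, the only earlier step at this place, a 1.3-fold higher number from compound 2 to compound 3 (0.11 log units; within the scatter), could not separate amino from hydroxy, so the sensitivity of this place appears only with dimethylamino. No measured evidence on the series accounts for this difference.

Still open, as far as these compounds go, is whether methylamino at this place reads with amino or with dimethylamino, which would show whether one added methyl is enough to raise the number. Also open, from the compounds shown here alone, is whether a ring amine such as morpholino, or a longer chain ending in amino, behaves like amino or like dimethylamino here.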